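A few compounds are considered here, and "the series" means these few. Any claim that something is new, unique, unknown or untested is made for them only; others in the source may bear on it.

Compound 1 `Cc1ccc(C2CCN(S(=O)(=O)c3c(C)cc(C)cc3C)CC2)cc1` was measured in an ADME assay on HCT-116 cells (Homo sapiens) for cytotoxicity, read by CellTiter-Glo, with a stated time of 72 h (a higher number here means a weaker inhibitor, a lower number a stronger inhibitor), and gave > 5000 nM, which is a limit of the assay rather than a number.
Compound 2 `Cc1ccc(S(=O)(=O)N2CCC(N3CCC(C)CC3)CC2)cc1C` gave > 5000 nM in this assay, again a limit and not a number.
Compound 3 `CC1CCN(C2CCN(S(=O)(=O)c3cccc(-c4ccc(Cl)cc4)c3)CC2)CC1` gave > 5000 nM in this assay, also a limit.

So compound 2 stands exactly where the other two measured compounds stand: the limit of > 5000 nM in this assay, at which 3 of the 3 values shown sit. Among the measured compounds shown here, none of the three reached a numerical value, and no pair of measured compounds differs in only one place, so no measured step is available to show how a change in the sulfonyl-bound aryl group moves the result.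

Compound 4 `CC1CCN(C2CCN(S(=O)(=O)c3ccc(F)cc3F)CC2)CC1` has not yet been measured. It differs from compound 2 in one place: 2,4-difluorophenyl in place of 3,4-dimethylphenyl on a sulfonyl sulfur.

With all measured values sitting at the same limit, the expected step that the limit leaves unreadable from compound 2 to compound 4 is none beyond the scatter, in neither direction. Compound 4 is therefore expected to give about 8000 nM in this assay, most likely reported again as a limit, with a range from 3000 nM to 20000 nM.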

Compound 4, half-maximal inhibitory concentration: > 5000 nM
Compound 4 was reported as a limit; the forecaster's own chance of this, stated with the estimate: 80%; the middle value lies beyond the limit too.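

No step can be read between compound 2 and compound 4, where 2,4-difluorophenyl stands in place of 3,4-dimethylphenyl, because both results are limits: the limit of > 5000 nM in this assay, at which 4 of the 4 values shown sit. The compounds shown leave open whether any group on the sulfonyl sulfur can bring a numerical value in this assay.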